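Methyl on the saturated ring: compound 3 to compound 4

This account rests on a few compounds, and the source may have more. Where it says the series, first, only, none or still open, it means among the compounds named here.

Measured compounds:
compound 1 `COc1cc2c(Oc3ccc(NC(=O)c4nn(-c5ccccc5C)c(=O)cc4C)cc3F)ccnc2cc1OCCCN1CCC(C)CC1`, 2810 nM
compound 2 `COc1cc2c(Oc3ccc(NC(=O)c4nn(-c5ccccc5OC(F)(F)F)c(=O)cc4C)cc3F)ccnc2cc1OCCCN1CCC(C)CC1`, 250 nM
compound 3 `COc1cc2c(Oc3ccc(NC(=O)c4nn(-c5ccc(Cl)cc5Cl)c(=O)cc4C)cc3F)ccnc2cc1OCCCN1CCCCC1`, 290 nM

In a functional assay on HT-29 cells (Homo sapiens) for inhibition, read by MTT assay, with a stated time of 72 h (on this read-out lower numbers stand for stronger inhibition and higher numbers for weaker inhibition), compound 3 stands second highest of the three numbers; its nearest neighbour is compound 2, within the scatter, and its furthest is compound 1, beyond it. Compound 4 `COc1cc2c(Oc3ccc(NC(=O)c4nn(-c5ccc(Cl)cc5Cl)c(=O)cc4C)cc3F)ccnc2cc1OCCCN1CCC(C)CC1` differs from compound 3 by methyl in place of hydrogen on a saturated ring carbon, read one bond further out as piperidin-1-yl to 4-methylpiperidin-1-yl. Among the measured compounds shown here, the only measured step, an 11-fold lower number from compound 1 to compound 2 (1.05 log units; beyond the scatter), concerns a different part of the molecule and does not bear on this change; no measured pair differs in this way. For compound 4 the expected step is therefore no change at the digits printed from compound 3 to compound 4 (within the scatter), none beyond the scatter. Compound 4 is estimated at 290 nM, between 120 nM and 700 nM.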

Compound 4, half-maximal inhibitory concentration: 170 nM
Beside the measured number, compound 4's estimate is 1.7-fold (0.23 log units) above it; measured number inside the range.
By their numbers in this assay, from the lowest: compounds 4, 2 and 3 (each within the scatter of the next); then compound 1.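

In this assay, methyl in place of hydrogen on this saturated ring carbon gives a step within the scatter (a 1.7-fold lower number from compound 3 to compound 4 (0.23 log units; within the scatter)). With 4-methylpiperidin-1-yl held constant, 2,4-dichlorophenyl on the aromatic nitrogen matches 2-(trifluoromethoxy)phenyl within the scatter (a 1.5-fold lower number from compound 2 to compound 4 (0.17 log units; within the scatter)) but clearly outdoes 2-methylphenyl (a 17-fold lower number from compound 1 to compound 4 (1.22 log units; beyond the scatter)). No evidence is at hand that accounts for these steps.

Going by these compounds, whether the methyl step would read the same with 2-methylphenyl or 2-(trifluoromethoxy)phenyl on the aromatic nitrogen stays open. So does the outcome of ethyl or hydroxyl on this ring carbon, or of morpholin-4-yl in place of the piperidine.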